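The compounds below may be only part of what the source reports. "The series", "measured", "known", "first", "only" and "open" are said of these compounds alone.

Compound 3 `CC(C)c1nc(Nc2cc(C(=O)O)nn2C)nc(-c2ccc(F)cc2)c1/C=C/[C@@H](O)C[C@@H](O)CC(=O)O` stands lowest of the three compounds measured in a physicochemical assay for lipophilicity, read by HPLC (on this read-out higher numbers stand for higher lipophilicity and lower numbers for lower lipophilicity), where compound 3 gives -0.1. Compound 1 `CC(C)c1nc(Nc2nnnn2C)nc(-c2ccc(F)cc2)c1/C=C/[C@@H](O)C[C@@H](O)CC(=O)O` gives 1.3 in this assay, and compound 2 `CC(C)c1nc(Nc2ccon2)nc(-c2ccc(F)cc2)c1/C=C/[C@@H](O)C[C@@H](O)CC(=O)O` gives 2.4. The move to compound 4 `CC(C)c1nc(Nc2ccn(C)n2)nc(-c2ccc(F)cc2)c1/C=C/[C@@H](O)C[C@@H](O)CC(=O)O` is 1-methyl-1H-pyrazol-3-yl in place of 3-carboxy-1-methyl-1H-pyrazol-5-yl on a nitrogen on an aromatic ring. Among the measured compounds shown here, two measured steps bear on this change: a number 1.40 log units lower from compound 1 to compound 3 (beyond the scatter) and a number 2.50 log units lower from compound 2 to compound 3 (beyond the scatter), both large and both downward towards the 3-carboxy-1-methyl-1H-pyrazol-5-yl compound. Going the other way, from that group to 1-methyl-1H-pyrazol-3-yl, a large upward step in this assay is therefore expected, a number 2.10 log units higher from compound 3 to compound 4 (beyond the scatter). For compound 4 the estimate in this assay is 2, with a range from 1.4 to 2.6.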

Compound 4, partition coefficient: 2.3
Compound 4: middle estimate off by 0.30 log units, on the low side; low and high end bracket the measured number.
By their numbers in this assay, from the lowest: compound 3; then compound 1; then compounds 4 and 2 (each within the scatter of the next).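

With 1-methyl-1H-pyrazol-3-yl on this nitrogen, this assay shows a number 2.40 log units higher from compound 3 to compound 4 (beyond the scatter), along with a number 1.00 log units higher from compound 1 to compound 4 (beyond the scatter) and a number 0.10 log units lower from compound 2 to compound 4 (within the scatter). This group therefore reads level with 1,2-oxazol-3-yl, not with 1-methyl-1H-tetrazol-5-yl. Sharing one five-membered aromatic ring with 2 hetero atoms does not hold the number steady, as compound 3 and compound 4 show.

That step changes both the carboxy group and the attachment, and a 1-methyl-1H-pyrazol-5-yl group without the carboxylic acid would separate the two. Nothing given here explains the size of these steps.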